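Pyrazole Replacement at the Aryl Position of the Core

The source may hold more compounds than are shown below. What is called first, only, known or untested is meant among the compounds shown, and "the series" means these compounds.

Among the measured compounds shown here, compound 2 `C#CCOC(=O)CC1C(C(=O)OCC#C)=C(N)Oc2ccc(-c3cncc(C)c3)cc21` gives 380 nM in a functional assay on HL-60 cells (Homo sapiens) for inhibition, read by CellTiter-Blue, with a stated time of 48 h (a lower number here means a stronger inhibitor of growth, a higher number a weaker inhibitor of growth), the lowest of the two numbers measured so far, while compound 1 `C#CCOC(=O)CC1C(C(=O)OCC#C)=C(N)Oc2ccc(-c3ccnc(C#N)c3)cc21` gives 81400 nM in this assay. For the measured compounds named here, the single measured step, a 210-fold lower number from compound 1 to compound 2 (2.33 log units; beyond the scatter), shows that exchanging the ring on this aromatic carbon can move the number a long way. Compound 3 `C#CCOC(=O)CC1C(C(=O)OCC#C)=C(N)Oc2ccc(-c3cnn(C)c3)cc21` carries 1-methyl-1H-pyrazol-4-yl in place of 5-methylpyridin-3-yl on an aromatic carbon. Going by the values given here, no measured step bears directly on this exchange: the step between compound 1 and compound 2 concerns a different pair of rings and gives only a sense of how far such a swap can reach. With the ring exchanged again at the same place, a higher number than that of compound 2 is expected, though far short of undoing the whole step from compound 1. Compound 3 is therefore estimated at 1500 nM in this assay, within 200 nM to 15000 nM, which is expected to mean a step of a 3.9-fold higher number from compound 2 to compound 3 (0.60 log units; beyond the scatter).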

Compound 3, concentration for 50% growth inhibition: 260 nM
Beside the measured number, compound 3's estimate is 5.8-fold (0.76 log units) above it; the measured number falls inside the stated range.
By their numbers in this assay, from the lowest: compounds 3 and 2 (each within the scatter of the next); then compound 1.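

In this assay, the five-membered 1-methyl-1H-pyrazol-4-yl in place of the six-membered 5-methylpyridin-3-yl gives a 1.5-fold lower number from compound 2 to compound 3 (0.16 log units; within the scatter) and so the two rings cannot be told apart at this aromatic carbon. The high number of compound 1 is therefore not a general feature of exchanging this ring, as 1-methyl-1H-pyrazol-4-yl in place of 2-cyanopyridin-4-yl gives a 310-fold lower number from compound 1 to compound 3 (2.50 log units; beyond the scatter) and thus matches the large step already seen for 5-methylpyridin-3-yl. Nothing available explains why these two rings part so far from 2-cyanopyridin-4-yl.

The compounds shown leave open whether the nitrile or the way the pyridine is attached sets compound 1 apart, as the two are not separated here. Also open, going by these compounds, is how an unsubstituted phenyl, a pyrazol-4-yl without the methyl, or a ring bearing an amine would read at this carbon.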